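Adding bromine and moving fluorine on the cytotoxic scaffold

The compounds below may be only part of what the source reports. "The series", "measured", "known", "first", "only" and "open" are said of these compounds alone.

Measured in a functional assay on MCF7 cells (Homo sapiens) for cytotoxicity, read by CCK-8 assay, with a stated time of 72 h; a lower number here means a stronger inhibitor, a higher number a weaker inhibitor:
- compound 1 `COc1ccccc1/C=c1/[nH]c(=O)/c(=C\c2ccccc2OC)n(C)c1=O` gives 9000 nM
- compound 2 `C=CCn1c(=O)/c(=C\c2cccc(F)c2)[nH]c(=O)/c1=C\c1ccccc1OC` gives 13700 nM

Compound 2 and compound 1 sit within the usual scatter of each other in this assay, so neither can be called the stronger inhibitor. Compound 3 `C=CCn1c(=O)/c(=C\c2cc(Br)ccc2F)[nH]c(=O)/c1=C\c1ccccc1OC` is not yet measured. It differs from compound 2 by 5-bromo-2-fluorophenyl in place of 3-fluorophenyl on a double-bonded chain carbon bound to an aromatic carbon. Among the measured compounds shown here, no measured pair shows what this kind of change does here, so the step from compound 2 to compound 3 in this assay is expected to stay within the scatter, in no clear direction: a 1.2-fold lower number from compound 2 to compound 3 (0.10 log units; within the scatter). Compound 3 is therefore estimated at 11000 nM, with a range from 3500 nM to 35000 nM.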

Compound 3, half-maximal inhibitory concentration: 28100 nM
For compound 3 the middle estimate is 2.6-fold (0.41 log units) below the measured one; low and high end bracket the measured number.
By their numbers in this assay, from the lowest: compounds 1 and 2 (each within the scatter of the next); then compound 3.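

In this assay, placing 5-bromo-2-fluorophenyl where 3-fluorophenyl stood gives a 2.1-fold higher number from compound 2 to compound 3 (0.31 log units; beyond the scatter). Among the compounds shown here, this modest step is the first comparison here that shows this position responding to a change in its aromatic group, and it moves toward weaker inhibition. Nothing available explains the shift.

The swap adds bromine and moves fluorine at once, so the compounds shown cannot separate the share of each. Also open, as far as these compounds go, is how a phenyl group carrying an amine or a carboxylic acid would fare in this assay.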